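Chain variation on the shared core: butyl to cyclopropylmethyl

This account rests on a few compounds, and the source may have more. Where it says the series, first, only, none or still open, it means among the compounds named here.

Compound 1 `CCc1c(C(N)C(=O)O)cnn1O` gives 57000 nM; 56200 nM (2 entries) in a functional assay on CHO cells for agonist activity at metabotropic glutamate receptor 2 (Rattus norvegicus), read by cAMP accumulation; on this read-out lower numbers stand for an effect already at smaller amounts and higher numbers for an effect only at larger amounts of compound. Compound 2 `CCCCc1c(C(N)C(=O)O)cnn1O` reaches only the limit of > 1000000 nM in this assay, so it stands at the weak end of the numbers shown, with no single number to set against compound 1. Compound 3 `NC(C(=O)O)c1cnn(O)c1CC1CC1` differs from compound 2 by cyclopropyl in place of propyl on a saturated chain carbon bound to an aromatic carbon. For the measured compounds named here, no single-change step has been measured, so the expected step of an at least 2.5-fold lower number from compound 2 to compound 3 (0.39 log units; beyond the scatter) is taken as modest and towards smaller amounts of compound. Compound 3 is therefore estimated at 400000 nM, within 60000 nM to 1500000 nM.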

Compound 3, half-maximal effective concentration: > 1000000 nM
Compound 3: no number, only a limit (the forecaster's own chance of this, stated with the estimate: 55%); middle value at least 2.5-fold (0.39 log units) away from the limit.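

Compound 2 and compound 3 give no readable step, since both stand only at a limit in this assay: the limit of > 1000000 nM in this assay, at which 2 of the 3 values shown sit.

The compounds shown leave open whether butyl and cyclopropylmethyl on the shared core differ at all on this read-out.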